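From a benzothiophene to an indole on the shared core

The source may hold more compounds than are shown below. What is called first, only, known or untested is meant among the compounds shown, and "the series" means these compounds.

Three compounds share one core and differ only in the group on one aromatic carbon. Compound 1 `Cc1cc(Cl)nnc1N1CCN(c2ncccn2)CC1` carries a chloro there; in a functional assay on BV-2 cells (Mus musculus) for inhibition, read by ELISA, with a stated time of 16 h (a lower number here means a stronger inhibitor, a higher number a weaker inhibitor), compound 1 gives > 100000 nM, which is a limit of the assay and not a number (the limit of > 100000 nM in this assay, at which 1 of the 3 values shown sits). Compound 2 `COc1cccc(-c2cc(C)c(N3CCN(c4ncccn4)CC3)nn2)c1` carries a 3-methoxyphenyl and gives 2600 nM in this assay. Compound 3 `Cc1cc(-c2cc3ccccc3s2)nnc1N1CCN(c2ncccn2)CC1` carries a 1-benzothiophen-2-yl and gives 24900 nM in this assay, the highest of the two numbers shown; the gap is a 9.6-fold higher number from compound 2 to compound 3 (0.98 log units; beyond the scatter). Replacing the chloro moved the number in both measured cases: an at least 38-fold lower number from compound 1 to compound 2 (1.58 log units; beyond the scatter) and an at least 4.0-fold lower number from compound 1 to compound 3 (0.60 log units; beyond the scatter). Compound 4 `Cc1cc(-c2ccc3[nH]ccc3c2)nnc1N1CCN(c2ncccn2)CC1` is not yet measured; it differs from compound 3 in one place: 1H-indol-5-yl in place of 1-benzothiophen-2-yl on an aromatic carbon. Among the measured compounds shown here, no measured step swaps one two-ring group for another, so direction and size are uncertain; the span between compound 2 and compound 3 suggests a moderate move is possible. Compound 4 is expected to land near 9000 nM, between 1500 nM and 45000 nM, which means an expected step of a 2.8-fold lower number from compound 3 to compound 4 (0.44 log units; beyond the scatter) in this assay.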

Compound 4, half-maximal inhibitory concentration: 85100 nM
Estimate against measurement, compound 4: 9.5-fold (0.98 log units) below, and the stated range ends below it.
By their numbers in this assay, from the lowest: compound 2; then compound 3; then compound 4. At a limit, above all of these: compound 1.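

Ring make-up alone does not set the number at this position: the 1-benzothiophen-2-yl and the 1H-indol-5-yl each hold one five-membered and one six-membered aromatic ring, yet the swap gives a 3.4-fold higher number from compound 3 to compound 4 (0.53 log units; beyond the scatter) in this assay, and the single-ring 3-methoxyphenyl stays well ahead, with a 33-fold higher number from compound 2 to compound 4 (1.51 log units; beyond the scatter). An aromatic group in place of the chloro therefore need not bring a clear gain, as this floor shows: an at least 1.1-fold lower number from compound 1 to compound 4 (0.07 log units; that floor lies within the scatter). Compound 1 stands at a limit of the assay, not at a number: the limit of > 100000 nM in this assay, at which 1 of the 4 values shown sits.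

The compounds shown do not separate the change of ring atom from the change in attachment point, which a 1H-indol-2-yl group would help to do. From the compounds shown here alone, how an amine or a carboxylic acid would behave on this aromatic carbon also stays open.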